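Swapping an ethyl for an amino on a thienopyridazinone core

The source may report more compounds than this note shows. Statements on the series, on what has been measured and on what is new or still open speak of the compounds shown alone.

Of the compounds shown here, three have been measured in an assay on CHO cells for displacement of a labelled ligand from adenosine receptor A1 (Homo sapiens), read by scintillation counting, with a stated time of 90 min; on this read-out lower numbers stand for stronger inhibition and higher numbers for weaker inhibition. Compound 1 `CCn1nc(-c2ccccn2)c2sccc2c1=O` gives 782 nM. Compound 2 `CCn1nc(-c2cccs2)c2sccc2c1=O` gives 724 nM; its core differs from that of compound 1 by thiophen-2-yl in place of pyridin-2-yl on an aromatic carbon, and a 1.1-fold lower number from compound 1 to compound 2 (0.03 log units; within the scatter). Compound 3 `Nn1nc(-c2ccccn2)c2sccc2c1=O` gives 3720 nM; the change amino in place of ethyl on an aromatic nitrogen gave a 4.8-fold higher number from compound 1 to compound 3 (0.68 log units; beyond the scatter). Compound 4 `Nn1nc(-c2cccs2)c2sccc2c1=O` awaits measurement in this assay. It differs from compound 2 by amino in place of ethyl on an aromatic nitrogen. The surroundings are not identical: in compound 1 the place is meta to a pyridin-2-yl group, in compound 2 meta to a thiophen-2-yl group, so this is the same kind of change rather than the same one. The expected step is a 4.8-fold higher number from compound 2 to compound 4 (0.68 log units; beyond the scatter), beside the measured 4.8-fold higher number from compound 1 to compound 3 (0.68 log units; beyond the scatter); this rests on compound 1 and compound 3. Compound 4 is expected to give about 3500 nM, estimated between 1500 nM and 8000 nM.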

Compound 4, inhibition constant: 3540 nM
Compound 4: middle estimate off by 1.0-fold (0.00 log units), on the low side, within the range that was stated.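

In this assay amino in place of ethyl on the aromatic nitrogen gave a 4.9-fold higher number from compound 2 to compound 4 (0.69 log units; beyond the scatter) and so weaker inhibition on this core too. The change carried from one core to the other, one bearing pyridin-2-yl and the other thiophen-2-yl, at a matching size: the same change on two cores in this assay, a 4.8-fold higher number (0.68 log units; beyond the scatter) from compound 1 to compound 3 and a 4.9-fold higher number (0.69 log units; beyond the scatter) from compound 2 to compound 4, 1.0-fold (0.01 log units) apart, within the scatter of two such steps

Going by these compounds alone, this rests on only two pairs of compounds, so it does not show that the change would behave the same way on a core bearing any other group, and it does not explain why inhibition weakens.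

Still open, on these data alone, is where a longer chain such as propyl, or a methylamino group, on the same nitrogen would fall relative to ethyl and amino. Also open, as far as these compounds go, is how the change would behave with a phenyl group in place of thiophen-2-yl.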